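The source may report more compounds than this note shows. Statements on the series, on what has been measured and on what is new or still open speak of the compounds shown alone.

Among the measured compounds shown here, in a functional assay on BSY-1 cells (Homo sapiens) for inhibition, read by sulforhodamine B assay, with a stated time of 48 h (on this read-out higher numbers stand for weaker inhibition of growth and lower numbers for stronger inhibition of growth), compound 1 `CCCCCCCCCCCC[C@@H](O)[C@H]1CC[C@H]([C@H](O)CCCCCCCCCCNC(=O)c2ccnn2C)O1` gives 10 nM, the lower of the two numbers so far, while compound 2 `CCCCCCCCCCCC[C@@H](O)[C@H]1CC[C@H]([C@H](O)CCCCCCCCCCNCc2ccnn2C)O1` gives 339 nM. Compound 3 `CCCCCCCCCCCC[C@@H](O)[C@H]1CC[C@H]([C@H](O)CCCCCCCCCCOC(=O)c2ccnn2C)O1` differs from compound 1 in one place: ((1-methyl-1H-pyrazol-5-yl)carbonyl)oxy in place of ((1-methyl-1H-pyrazol-5-yl)carbonyl)amino on a saturated chain carbon, ten or more bonds along the chain from an oxygen on a saturated carbon and a saturated ring carbon. For the measured compounds named here, the only measured step, a 34-fold higher number from compound 1 to compound 2 (1.53 log units; beyond the scatter), lost the carbonyl, which compound 3 retains, so that large step bears only indirectly on this change. A smaller rise is therefore expected, a 2.0-fold higher number from compound 1 to compound 3 (0.30 log units; within the scatter). The estimated value for compound 3 is 20 nM, with an expected range of 4 nM to 100 nM.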

Compound 3, concentration for 50% growth inhibition: 813 nM
Estimate against measurement, compound 3: 41-fold (1.61 log units) below; measured number outside the range, above it.
By their numbers in this assay, from the lowest: compound 1; then compound 2; then compound 3.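

In this assay, the amide link proves not to be interchangeable with the ester link of the same heavy-atom count, giving an 81-fold higher number from compound 1 to compound 3 (1.91 log units; beyond the scatter), so keeping the carbonyl does not by itself keep the low number. Putting the ester in place of the amine link restores the carbonyl yet still gives a 2.4-fold higher number from compound 2 to compound 3 (0.38 log units; beyond the scatter), a modest step. No measurement here accounts for these differences.

From the compounds shown here alone, it remains open whether a sulfonamide or urea at this place would match the amide. A methylated amide nitrogen would likewise be untested.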